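Swapping 4-nitrobenzyl for 3-fluorobenzyl

This account rests on a few compounds, and the source may have more. Where it says the series, first, only, none or still open, it means among the compounds named here.

In a functional assay on B16 cells (Mus musculus) for antiproliferative activity, read by MTT assay, with a stated time of 24 h (a higher number here means a weaker inhibitor, a lower number a stronger inhibitor), compound 3 (`COc1cc(OC)c(-c2coc3cc(OCc4ccc([N+](=O)[O-])cc4)ccc3c2=O)cc1OC`) gives > 10000 nM, a limit of the assay and not a number. Compound 1 (`COc1cc(OC)c(-c2coc3cc(OCC(=O)c4cccc(C(F)(F)F)c4)ccc3c2=O)cc1OC`) gives > 10000 nM, also a limit. This is the limit of > 10000 nM in this assay, at which 2 of the 3 values shown sit. Compound 2 (`COc1cc(OC)c(-c2coc3cc(OCc4ccccc4C)ccc3c2=O)cc1OC`) gives a true number, 2150 nM.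

Compound 4 (`COc1cc(OC)c(-c2coc3cc(OCc4cccc(F)c4)ccc3c2=O)cc1OC`) carries 3-fluorophenyl in place of 4-nitrophenyl on the same chain carbon: 3-fluorophenyl in place of 4-nitrophenyl on a saturated chain carbon bound to an oxygen on an aromatic ring. Going by the values given here, the closest measured change is an at least 4.6-fold higher number from compound 2 to compound 3 (0.66 log units; beyond the scatter), which also replaces only this ring. Another is an at least 4.6-fold lower number from compound 1 to compound 2 (0.66 log units; beyond the scatter). Both lie beyond the scatter, so this ring can matter, and compound 4 may resemble compound 2 at 2150 nM. The expected step is an at least 2.5-fold lower number from compound 3 to compound 4 (0.39 log units; beyond the scatter), toward a stronger inhibitor. Compound 4 is estimated at 4000 nM, with an expected range of 1500 nM to 10000 nM.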

Compound 4, half-maximal inhibitory concentration: 2440 nM
Compound 4: middle estimate off by 1.6-fold (0.21 log units), on the high side, within the range that was stated.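

In this assay, 3-fluorophenyl gives an at least 4.0-fold lower number from compound 3 to compound 4 (0.61 log units; beyond the scatter), and in place of (3-(trifluoromethyl)phenyl)carbonyl it gives an at least 4.0-fold lower number from compound 1 to compound 4 (0.61 log units; beyond the scatter). Against 2-methylphenyl it gives a 1.1-fold higher number from compound 2 to compound 4 (0.05 log units; within the scatter), so two different substituted phenyl rings on this chain carbon now give measurable values that lie within the scatter of each other, while 4-nitrophenyl does not. The two larger steps are open-ended, since compound 1 and compound 3 each sit at a limit of the assay: the limit of > 10000 nM in this assay, at which 2 of the 4 values shown sit.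

The compounds shown leave open whether the fluorine itself matters, since an unsubstituted phenyl ring is absent here. They also leave open how an amine or a carboxylic acid on this ring would behave.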